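Benzyl Replacing Hexyl on the Shared Core

The compounds below may be only part of what the source reports. "The series", "measured", "known", "first", "only" and "open" are said of these compounds alone.

Of the compounds shown here, two sharing one core have been measured in a functional assay on HEK293T cells for agonist activity at histamine H2 receptor (Homo sapiens), read by beta-arrestin recruitment; on this read-out higher numbers stand for larger maximal responses and lower numbers for smaller maximal responses. Compound 1 `Cc1nc(N)sc1CCCN/C(N)=N/C(=O)N[C@@H](C)c1ccccc1` carries a 1-phenylethyl group on its amide-type nitrogen, and in this assay compound 1 gives 0.46. Compound 2 `CCCCCCNC(=O)/N=C(\N)NCCCc1sc(N)nc1C` carries a hexyl group in that place, and in this assay compound 2 gives 0.28, the lower of the two numbers, with a difference a number 0.18 lower from compound 1 to compound 2 (beyond the scatter).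

Compound 3 `Cc1nc(N)sc1CCCN/C(N)=N/C(=O)NCc1ccccc1` is the next compound, with a change computed from the structures of compound 2 and compound 3: phenyl in place of pentyl on a saturated chain carbon bound to an amide-type nitrogen. Among the measured compounds shown here, the only measured step that bears on this change is the one in which hexyl replaced 1-phenylethyl, and benzyl differs from 1-phenylethyl by one methyl only, so the new step is expected to run in the opposite direction and to recover most of that loss.

For compound 3 the expected step is a number 0.14 higher from compound 2 to compound 3 (beyond the scatter). The estimate for compound 3 is therefore 0.42, with a range from 0.28 to 0.56.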

Compound 3, intrinsic activity: the largest response reached, as a fraction of the reference agonist's: 0.33
The estimate for compound 3 lay 0.090 above the measured number, within the range that was stated.
By their numbers in this assay, from the lowest: compounds 2 and 3 (each within the scatter of the next); then compound 1.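

Exchanging hexyl for benzyl on the shared core changes little in this assay (a number 0.050 higher from compound 2 to compound 3 (within the scatter)), so adding a phenyl ring at this position does not by itself set compound 3 apart from compound 2. The single methyl on the saturated chain carbon bound to an amide-type nitrogen and an aromatic carbon counts for more: with hydrogen in place of that methyl, the number falls (a number 0.13 lower from compound 1 to compound 3 (beyond the scatter)), which places compound 3 within the scatter of compound 2 and clearly apart from compound 1. In these three compounds, then, the higher maximal response of compound 1 goes with the phenyl ring and the methyl together, and nothing measured here explains why this small group matters.

On these data alone, it remains open whether an ethyl group on that same carbon, or the mirror-image arrangement of the methyl, would keep, enlarge or erase the gain seen with compound 1. As far as these compounds go, it is equally open whether a cyclohexylmethyl group, with a saturated ring in place of the phenyl ring, would behave like hexyl or like benzyl in this assay.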